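A few compounds are considered here, and "the series" means these few. Any claim that something is new, unique, unknown or untested is made for them only; others in the source may bear on it.

Working notes on the series. Compound 1 `O=C(Nc1ccnnc1)c1cc(C(F)(F)F)ccc1OCc1ccccc1` gives 15.9 nM in an assay on Sf9 cells for inhibition of Leucine-rich repeat serine/threonine-protein kinase 2 (Homo sapiens), read by TR-FRET, with stated times of 30 min and 2 h; a higher number here means a weaker inhibitor, a lower number a stronger inhibitor. Compound 2 `O=C(Nc1ccnnc1)c1cc(N2C[C@H]3COC[C@H]3C2)ccc1OCc1ccccc1` gives 50.1 nM, and compound 3 `O=C(Nc1ccnnc1)c1cc(N2CCC(F)CC2)ccc1OCc1ccccc1` gives 39.8 nM. Compound 3 thus stands second highest of the three numbers, nearest compound 2 and furthest from compound 1: a 1.3-fold lower number from compound 2 to compound 3 (0.10 log units; within the scatter) lies within the scatter, whereas a 2.5-fold higher number from compound 1 to compound 3 (0.40 log units; beyond the scatter) and a 3.2-fold higher number from compound 1 to compound 2 (0.50 log units; beyond the scatter) lie beyond it. Compound 4 `O=C(Nc1ccnnc1)c1cc(N2CCCC2)ccc1OCc1ccccc1` differs from compound 3 by pyrrolidin-1-yl in place of 4-fluoropiperidin-1-yl on an aromatic carbon. The step that bears most directly on this exchange of one saturated amine ring for another is a 1.3-fold lower number from compound 2 to compound 3 (0.10 log units; within the scatter), which stayed within the scatter; the modest rises from compound 1 concern a different group. A step within the scatter is therefore expected in this assay, estimated as a 1.0-fold higher number from compound 3 to compound 4 (0.00 log units; within the scatter). Compound 4 is expected at 40 nM, within 15 nM to 110 nM.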

Compound 4, half-maximal inhibitory concentration in the Leucine-rich repeat serine/threonine-protein kinase 2 assay: 20 nM
For compound 4 the middle estimate is 2.0-fold (0.30 log units) above the measured one, and the stated range covers the measured number.
By their numbers in the Leucine-rich repeat serine/threonine-protein kinase 2 assay, from the lowest: compounds 1, 4, 3 and 2 (each within the scatter of the next, the first and the last beyond it).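

In the Leucine-rich repeat serine/threonine-protein kinase 2 assay, a 2.0-fold lower number from compound 3 to compound 4 (0.30 log units; within the scatter) and a 1.3-fold higher number from compound 1 to compound 4 (0.10 log units; within the scatter) leave pyrrolidin-1-yl on this aromatic carbon not separable from either 4-fluoropiperidin-1-yl or trifluoromethyl. Within the data shown here, in contrast, a 2.5-fold lower number from compound 2 to compound 4 (0.40 log units; beyond the scatter) is the only step among the saturated amine rings at this position to pass the scatter. The exchange of 4-fluoropiperidin-1-yl for pyrrolidin-1-yl does, however, move a physicochemical assay for lipophilicity, at pH 7.4 (a lower number here means a more polar compound, a higher number a more lipophilic compound), clearly: the measured distribution coefficient of compound 3, 5.1, and of compound 4, 6.1, a number 1.00 log units higher (beyond the scatter) In the physicochemical assay compound 3 gives 5.1 and compound 4 gives 6.1 in this read-out.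

Compound 3 and compound 4 differ in both ring size and fluorine, so neither change can be singled out. As far as these compounds go, what a morpholine or a carboxylic acid on this aromatic carbon would give in the Leucine-rich repeat serine/threonine-protein kinase 2 assay and the physicochemical assay stays open.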